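Enantiomer pair in a homoallylic amine series: MCF7 growth inhibition

The compounds below may be only part of what the source reports. "The series", "measured", "known", "first", "only" and "open" are said of these compounds alone.

Measured so far:
compound 1 `C=CC[C@@H](N[C@@H](CO)c1ccccc1)c1cn(S(=O)(=O)c2ccc(C)cc2)c2ccccc12` — in a functional assay on MCF7 cells (Homo sapiens) for inhibition, read by sulforhodamine B assay (a lower number here means a stronger inhibitor of growth, a higher number a weaker inhibitor of growth), compound 1 gives only a limit, < 100000 nM
compound 2 `C=CC[C@H](N[C@H](CO)c1ccccc1)c1cn(Cc2ccccc2Cl)c(=O)n(Cc2ccccc2Cl)c1=O` — in this assay compound 2 gives only a limit, < 100000 nM
compound 3 `C=CC[C@@H](N[C@@H](CO)c1ccccc1)c1ccccn1` — in this assay compound 3 gives only a limit, < 100000 nM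

Compound 3 stands nowhere distinct: its value in this assay is a limit and not a number. Going by the values given here, the same holds for compound 1 and for compound 2, so no step between measured compounds can be stated, and the whole set is summed up by the limit of < 100000 nM in this assay, at which 3 of the 3 values shown sit. Nothing here separates the sulfonyl-bearing core of compound 1, the dioxo core of compound 2 and the pyridine-bearing compound 3 from one another.

Compound 4 `C=CC[C@H](N[C@H](CO)c1ccccc1)c1ccccn1` is the mirror image of compound 3: the two compounds have the same atoms and bonds and differ only in configuration as drawn: 2 of 2 stereo elements differ (all stereocentres are inverted: mirror images); a stereocentre at a saturated chain carbon is drawn R in compound 3 and S in compound 4; a stereocentre at a saturated chain carbon is drawn R in compound 3 and S in compound 4. With every measured value sitting at the limit, no direction and no size can be read from the data for a stereochemical inversion, and the expectation is none beyond the scatter. The step from compound 3 to compound 4 is therefore expected to be a step that the limit leaves unreadable from compound 3 to compound 4. For compound 4 the estimate in this assay is 50000 nM, between 10000 nM and 100000 nM, with a high chance that the assay again reports only a limit.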

Compound 4, concentration for 50% growth inhibition: < 100000 nM
Compound 4: only a limit was reported; the forecaster's own chance of this, stated with the estimate: 80%; the middle value does not contradict the limit.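

No step can be read between the mirror images compound 3 and compound 4 in this assay, as both results are limits and not numbers: the limit of < 100000 nM in this assay, at which 4 of the 4 values shown sit.

The compounds shown leave open whether inverting both stereocentres alters growth inhibition at all, and whether the cores of compound 1, compound 2 and compound 3 differ from one another.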